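Antiproliferative purine series: three limits and one open question

This account rests on a few compounds, and the source may have more. Where it says the series, first, only, none or still open, it means among the compounds named here.

Measured so far:
compound 1 `CCCCCC(CCO)n1cnc2c(NC)ncnc21`: > 50000 nM
compound 2 `CCCCCC(CCO)n1cnc2c(N)ncnc21`: > 50000 nM
compound 3 `CCCCCCC(CCO)n1cnc2c(NC)ncnc21`: > 50000 nM

All three values in a functional assay on SW480 cells (Homo sapiens) for antiproliferative activity, read by MTT assay, with a stated time of 48 h (a lower number here means a stronger inhibitor, a higher number a weaker inhibitor), are limits of the assay and not numbers. For compound 1 the result is a limit, > 50000 nM. For compound 2 the result is likewise a limit, > 50000 nM. For compound 3 the result is again a limit, > 50000 nM. This is summed up by the limit of > 50000 nM in this assay, at which 3 of the 3 values shown sit.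

Two changes connect the measured compounds. From compound 2 to compound 1 the change is methyl in place of hydrogen on a nitrogen on an aromatic ring and the step is a step that the two limits leave unreadable from compound 2 to compound 1. The further step that the two limits leave unreadable from compound 1 to compound 3 is equally unreadable. The difference between the cores of compound 2 and compound 3 is not broken down here.

Compound 4 `CCCCCCC(CCO)n1cnc2c(N(C)C)ncnc21` has not been measured. It differs from compound 3 by methyl in place of hydrogen on a nitrogen on an aromatic ring. This is the same kind of change as that from compound 2 to compound 1, not the same: there the nitrogen's other neighbour is an aromatic carbon, here the other neighbours are an aromatic carbon and a saturated chain carbon. Since every measured compound sits at the limit, as the limit of > 50000 nM in this assay, at which 3 of the 3 values shown sit, shows, there is no readable step on which an expectation could rest beyond that.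

For compound 4 the step that the limit leaves unreadable from compound 3 to compound 4 is therefore expected to be small or unreadable. The estimate for compound 4 in this assay is 60000 nM, with a range from 20000 nM to 150000 nM, and most likely the assay will again report only a limit.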

Compound 4, half-maximal inhibitory concentration: > 50000 nM
Compound 4: only a limit was reported; the forecaster's own chance of this, stated with the estimate: 85%; the middle value lies beyond the limit too.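

Between compound 3 and compound 4 no step can be read, since compound 4, like compound 3, gives only a limit in this assay: the limit of > 50000 nM in this assay, at which 4 of the 4 values shown sit.

The compounds shown leave open whether any member of this series reaches a readable value in this assay, and so what size a change such as methylamino to dimethylamino has on the shared core.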